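Halogen-Free Benzamide on a Weakly Active Core

This account rests on a few compounds, and the source may have more. Where it says the series, first, only, none or still open, it means among the compounds named here.

Compound 1 `O=C(Nc1ccc(Cl)c(-c2nnc3c(Cl)cccn23)c1)c1ccc(F)cc1Cl` gives > 100000 nM in a functional assay on MDA-MB-468 cells (Homo sapiens) for antiproliferative activity, read by MTT assay, with a stated time of 72 h (on this read-out lower numbers stand for stronger inhibition and higher numbers for weaker inhibition), a limit rather than a number.
Compound 2 `O=C(Nc1ccc(Cl)c(-c2nnc3c(Cl)cccn23)c1)c1ccc(Cl)cc1` gives > 100000 nM in this assay, also a limit.
Compound 3 `O=C(Nc1ccc(Cl)c(-c2nnc3c(Cl)cccn23)c1)c1c(F)cccc1Cl` gives 57600 nM in this assay.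

Compound 3 holds the only actual number shown; the other two values sit at the limit of > 100000 nM in this assay, at which 2 of the 3 values shown sit. Compound 4 `O=C(Nc1ccc(Cl)c(-c2nnc3c(Cl)cccn23)c1)c1ccccc1` differs from it in one place: phenyl in place of 2-chloro-6-fluorophenyl on a carbonyl carbon. Among the compounds with values here, the steps that bear on this change are an at least 1.7-fold lower number from compound 1 to compound 3 (0.23 log units; that floor lies within the scatter) and an at least 1.7-fold lower number from compound 2 to compound 3 (0.23 log units; that floor lies within the scatter), both floors that lie within the scatter, while a step that the two limits leave unreadable from compound 1 to compound 2 cannot be read. Compound 2, which also lacks the 2-chloro-6-fluorophenyl, gives > 100000 nM, a limit. A step of a 1.7-fold higher number from compound 3 to compound 4 (0.24 log units; within the scatter) toward weaker inhibition is therefore expected, probably back to a limit. Compound 4 is estimated at 100000 nM, with a range from 40000 nM to 300000 nM.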

Compound 4, half-maximal inhibitory concentration: > 100000 nM
Compound 4 ended at the assay's limit (the forecaster's own chance of this, stated with the estimate: 70%); the middle value sits exactly at the limit.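

At this place on the carbonyl carbon, phenyl in place of 2-chloro-6-fluorophenyl gives an at least 1.7-fold higher number from compound 3 to compound 4 (0.23 log units; that floor lies within the scatter), so the step's measurable floor does not separate the halogen-free ring from compound 3. Compound 4 thus adds the bare phenyl to the compounds at the limit: the limit of > 100000 nM in this assay, at which 3 of the 4 values shown sit. The steps among compound 1, compound 2 and compound 4 join two limits and cannot be read.

As far as these compounds go, how far the number would move with an amine or a carboxylic acid on the ring, or with cyclohexyl in place of phenyl, stays open.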